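Swapping the substituted phenyl on the isoxazole in a triazole series

A few compounds are considered here, and "the series" means these few. Any claim that something is new, unique, unknown or untested is made for them only; others in the source may bear on it.

Measured compounds:
Compound 1, `O=[N+]([O-])c1ccc(CN2CCC(n3cc(CC(OCc4cc(-c5ccccc5)no4)c4ccc(Br)cc4)nn3)CC2)cc1`, gives 7000 nM in a functional assay on Caco-2 cells (Homo sapiens) for cytotoxicity, with a stated time of 48 h; on this read-out lower numbers stand for stronger inhibition and higher numbers for weaker inhibition.
Compound 2, `O=[N+]([O-])c1ccc(CN2CCC(n3cc(CC(OCc4cc(-c5cccc(F)c5)no4)c4ccc(Br)cc4)nn3)CC2)cc1`, gives 5000 nM in this assay.
Compound 3, `N#Cc1cccc(-c2cc(COC(Cc3cn(C4CCN(Cc5ccc([N+](=O)[O-])cc5)CC4)nn3)c3ccc(Br)cc3)on2)c1`, gives 3000 nM in this assay.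

Compound 3 has the lowest of the three numbers; its gap to compound 2 lies within the scatter, while the step of a 2.3-fold lower number from compound 1 to compound 3 (0.37 log units; beyond the scatter) lies beyond it, so it cannot be called the strongest outright. Compound 4, `O=[N+]([O-])c1ccc(CN2CCC(n3cc(CC(OCc4cc(-c5ccccc5F)no4)c4ccc(Br)cc4)nn3)CC2)cc1`, differs from compound 3 by 2-fluorophenyl in place of 3-cyanophenyl on an aromatic carbon. Going by the values given here, two measured steps bear on this: a 1.7-fold lower number from compound 2 to compound 3 (0.22 log units; within the scatter) and a 2.3-fold lower number from compound 1 to compound 3 (0.37 log units; beyond the scatter), both favouring the cyano. Among the compounds with values here, removing the nitrile is therefore expected to move the number back toward compounds 1 and 2, and the fluorine at its new position has no measured precedent. The estimated step is a 1.8-fold higher number from compound 3 to compound 4 (0.26 log units; within the scatter). Compound 4 is expected to give about 5500 nM in this assay, within 2500 nM to 12000 nM.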

Compound 4, half-maximal inhibitory concentration: 4000 nM
Compound 4: middle estimate off by 1.4-fold (0.14 log units), on the high side; the measured number falls inside the stated range.
By their numbers in this assay, from the lowest: compounds 3, 4, 2 and 1 (each within the scatter of the next, the first and the last beyond it).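

In this assay, the change to 2-fluorophenyl gives a 1.3-fold higher number from compound 3 to compound 4 (0.12 log units; within the scatter) and a 1.3-fold lower number from compound 2 to compound 4 (0.10 log units; within the scatter), so neither removing the nitrile nor placing the fluorine differently separates these compounds. Even against the unsubstituted phenyl, the change gives a 1.8-fold lower number from compound 1 to compound 4 (0.24 log units; within the scatter) and does not clear the scatter, unlike the nitrile of compound 3. Nothing available here explains these numbers. Still open, going by these compounds, is whether an amine or a carboxylic acid on this phenyl would shift the number beyond the scatter of this narrow set.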